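The compounds below may be only part of what the source reports. "The series", "measured", "known", "first", "only" and "open" are said of these compounds alone.

Compound 1 `O=c1c(C2N=C(c3ccccc3)SS2)coc2cc(Cl)ccc12` gives 57500 nM in a functional assay on A549 cells (Homo sapiens) for inhibition, read by sulforhodamine B assay, with a stated time of 48 h; a lower number here means a stronger inhibitor, a higher number a weaker inhibitor. Compound 2 `O=c1c(C(=S)Nc2ccccc2)coc2ccccc12` gives 52800 nM in this assay, and compound 3 `O=c1c(C(=S)Nc2ccccc2)coc2ccc(F)cc12` gives 71900 nM there. The difference between the cores of compound 1 and compound 2 is not broken down here. Compound 3 carries fluoro in place of hydrogen on an aromatic carbon, and this change produced a 1.4-fold higher number from compound 2 to compound 3 (0.13 log units; within the scatter). Compound 4 `O=c1c(C2N=C(c3ccccc3)SS2)coc2cc(Cl)c(F)cc12` has not yet been measured in this assay; it carries fluoro in place of hydrogen on an aromatic carbon, the same kind of change, though in compound 4 the place is also ortho to a chloro group. The step from compound 1 to compound 4 in this assay is expected to be small, a 1.2-fold higher number from compound 1 to compound 4 (0.09 log units; within the scatter), because the like change gave a 1.4-fold higher number from compound 2 to compound 3 (0.13 log units; within the scatter). Compound 4 is therefore estimated at 70000 nM, with an expected range from 35000 nM to 140000 nM.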

Compound 4, half-maximal inhibitory concentration: 93500 nM
Compound 4: the middle estimate sits 1.3-fold (0.13 log units) below what was measured; the range from low to high includes it.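

In this assay, the step for fluoro in place of hydrogen on an aromatic carbon reads a 1.6-fold higher number from compound 1 to compound 4 (0.21 log units; within the scatter). Set beside the earlier step, the change reads alike on both cores: the same change on two cores in this assay, a 1.4-fold higher number (0.13 log units; within the scatter) from compound 2 to compound 3 and a 1.6-fold higher number (0.21 log units; within the scatter) from compound 1 to compound 4, 1.2-fold (0.08 log units) apart, within the scatter of two such steps

On these two cores, then, the change carries over with no difference that can be told from the scatter, even though in compound 4 the place is ortho to a chloro group. Neither step shows a real effect of the fluoro group, and two cores say nothing about a third.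

The compounds shown leave open whether a larger group at this place, such as a methoxy group or an amine, would give a step beyond the scatter. They also leave open whether a carboxylic acid on the phenyl ring of compound 1 would do so.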